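The source may report more compounds than this note shows. Statements on the series, on what has been measured and on what is new or still open speak of the compounds shown alone.

In a functional assay on MCF7 cells (Homo sapiens) for antiproliferative activity, read by MTT assay, with a stated time of 72 h (on this read-out lower numbers stand for stronger inhibition and higher numbers for weaker inhibition), three compounds sharing a core have been tested so far. Compound 1 (`O=C(N/N=C/c1ccc(Br)cc1)Nc1ccc(Oc2ccnc3[nH]ccc23)cc1`) is reported as "not active" (no number reported), with no number given. Compound 2 (`O=C(N/N=C/c1ccc(F)cc1)Nc1ccc(Oc2ccnc3[nH]ccc23)cc1`) gives 3720 nM. Compound 3 (`CCN(CC)CCCn1cccc1/C=N/NC(=O)Nc1ccc(Oc2ccnc3[nH]ccc23)c(F)c1`), which carries a 3-(diethylamino)propyl chain, gives 3390 nM. The numbers for compound 2 and compound 3 lie within the usual scatter of each other, so compound 3 stands level with compound 2.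

Compound 4 (`O=C(N/N=C/c1cccn1CCCN1CCCC1)Nc1ccc(Oc2ccnc3[nH]ccc23)c(F)c1`) has not yet been measured. It differs from compound 3 in one place: pyrrolidin-1-yl in place of diethylamino on a saturated chain carbon, three bonds along the chain from an aromatic nitrogen. The chain thus becomes 3-(pyrrolidin-1-yl)propyl. Among the measured compounds shown here, no two measured compounds differ in only one place, so the data hold no direct precedent for this change. No step beyond the scatter is expected in this assay, in either direction, and the expectation rests on compound 3 at 3390 nM. The estimated change is a 1.1-fold lower number from compound 3 to compound 4 (0.05 log units; within the scatter). For compound 4, the estimated value is 3000 nM, with an expected range of 1200 nM to 7500 nM.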

Compound 4, half-maximal inhibitory concentration: 4580 nM
Compound 4: middle estimate off by 1.5-fold (0.18 log units), on the low side; the measured number falls inside the stated range.
By their numbers in this assay, from the lowest: compounds 3, 2 and 4 (each within the scatter of the next).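

Among the compounds shown here, compounds 3 and 4 are the only pair here that differ in one place, and in this assay their step reads a 1.4-fold higher number from compound 3 to compound 4 (0.13 log units; within the scatter). So on a saturated chain carbon, three bonds along the chain from an aromatic nitrogen, pyrrolidin-1-yl in place of diethylamino leaves the two compounds level, and at this position a ring and an open-chain group of the same heavy-atom count cannot be told apart on this read-out. No measurement at hand explains this result.

Going by these compounds, whether a larger ring such as piperidine, a morpholine, a dimethylamino group or a carboxylic acid at the same chain end would also stay level remains open. So does the effect of a shorter or longer chain carrying the pyrrolidin-1-yl group.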